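A few compounds are considered here, and "the series" means these few. Any claim that something is new, unique, unknown or untested is made for them only; others in the source may bear on it.

Compound 1 `CCOc1ccc(-n2cnnc2CC)cc1` and compound 2 `CCCCOc1ccc(-n2cnnc2CC)cc1` share the same core. In a functional assay on the whole organism (strain C57B/6) with Mus musculus as the target, in the maximal electroshock model (on this read-out lower numbers stand for an effect already at smaller amounts and higher numbers for an effect only at larger amounts of compound), compound 1 gives > 100 mg/kg, which is a limit of the assay rather than a number. In this assay compound 2 gives > 100 mg/kg, again a limit. The step that the two limits leave unreadable from compound 1 to compound 2 therefore cannot be read, since both values sit at the limit of > 100 mg/kg in this assay, at which 2 of the 2 values shown sit. Compound 3 `CCCCCCCCOc1ccc(-n2cnnc2CC)cc1` differs from compound 2 by butyl in place of hydrogen on a saturated chain carbon, four bonds along the chain from an oxygen on an aromatic ring. Among the measured compounds shown here, the one measured step bears on this change yet gives no size, so compound 3 is expected to show a step that the limit leaves unreadable from compound 2 to compound 3 that most likely ends again at the limit. Compound 3 is therefore estimated at 150 mg/kg, between 50 mg/kg and 500 mg/kg.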

Compound 3, dose for half-maximal effect: 8.8 mg/kg
The estimate for compound 3 lay 17-fold (1.23 log units) above the measured number; measured number below the stated range.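

In this assay, the chain on the oxygen turns out to matter at this position, which the earlier pair could not show: adding butyl gives an at least 11-fold lower number from compound 2 to compound 3 (1.05 log units; beyond the scatter), and adding hexyl to the shorter chain gives an at least 11-fold lower number from compound 1 to compound 3 (1.05 log units; beyond the scatter). The step between the two shorter chains still cannot be read. The full size of both new steps also stays unknown because compounds 1 and 2 stand at a limit rather than a number: the limit of > 100 mg/kg in this assay, at which 2 of the 3 values shown sit.

Going by these compounds, whether a longer chain, such as decyl, would lower the number further remains open. So does the effect of an amine at the chain end.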